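The compounds below may be only part of what the source reports. "The series", "measured", "known", "first", "only" and "open" are said of these compounds alone.

Measured so far in an ADME assay on microsomes from liver (Mus musculus) for metabolic stability, read by LC-MS, with a stated time of 30 min, tested at 1 uM; a higher number here means that more of the compound is left, a lower number that less of the compound is left:
compound 1 `Cc1cccc(S(=O)(=O)c2ccc(CNC(=O)c3cc4cnccc4[nH]3)cc2)c1`: 32%
compound 2 `O=C(NCc1ccc(S(=O)(=O)N2CCCCC2)cc1)c1cc2ccncc2[nH]1`: "below limit of detection" (no number reported)
compound 3 `CC(NC(=O)c1cc2cnccc2[nH]1)c1ccc(S(=O)(=O)N2CCCCC2)cc1`: 0.65%

All three share one core and carry a sulfonyl group on the outer ring. In this assay compound 1 gives 32%, the higher of the two numbers in hand. Among the measured compounds shown here, compound 3 gives 0.65%, a number lower than that of compound 1 by more than the scatter; the two structures differ in more than one place, so no single step between them is assigned. The result for compound 2 is a limit of the assay and not a number. Compound 4 `O=C(NCc1ccc(S(=O)(=O)c2ccc(F)cc2)cc1)c1cc2cnccc2[nH]1` has not yet been measured. It differs from compound 1 in one place only: 4-fluorophenyl in place of 3-methylphenyl on a sulfonyl sulfur. For the measured compounds named here, no measured pair isolates this change, so any expectation rests on compound 1 alone, and the direction of the step in this assay is open. The change from 3-methylphenyl to 4-fluorophenyl on the sulfonyl sulfur is expected to move the percent remaining only slightly upward, a step of a number 8 percentage points higher from compound 1 to compound 4 (within the scatter) that may not clear the scatter. Compound 4 is accordingly estimated at 40%, with a range from 20% to 65%.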

Compound 4, percent of the compound remaining: 72%
Estimate against measurement, compound 4: 32 percentage points below; measured number above the stated range.
By their numbers in this assay, from the lowest: compound 3; then compound 1; then compound 4.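

Among the compounds shown here, on the sulfonyl sulfur whose other neighbour is an aromatic carbon, the outer group is not a silent place: in this assay, putting 4-fluorophenyl in place of 3-methylphenyl gives a number 40 percentage points higher from compound 1 to compound 4 (beyond the scatter), and this is the first step confined to one place. The counts do not separate the two groups, since each has the same number of heavy atoms, one six-membered aromatic ring of carbon only, no hydrogen-bond donors or acceptors and no net charge, so a large step in percent remaining can arise here with all of these unchanged. No measurement bears on what lies behind this step.

The two names differ both in the substituent and in its number on the ring, and this single pair cannot tell the loss of methyl, the gain of fluorine and the change of ring position apart; unsubstituted phenyl, 4-methylphenyl and 3-fluorophenyl would separate them. From the compounds shown here alone, it also remains open whether the step carries over to other groups on the sulfur, such as 4-chlorophenyl or 4-methoxyphenyl, or to other versions of the core.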